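Shifting acid and fluorine on the far ring

The source may hold more compounds than are shown below. What is called first, only, known or untested is meant among the compounds shown, and "the series" means these compounds.

Four compounds share one core. Compound 1 `Cc1c(OCCCCOc2ccc(C(=O)O)cc2F)ccc(C(=O)CC2CCCC2)c1O` and compound 3 `Cc1c(OCCCCOc2ccc(C(=O)O)cc2F)ccc(C(=O)CC(C)C)c1O` were tested in an assay on HEK293 cells for positive allosteric modulation of metabotropic glutamate receptor 2 (Rattus norvegicus), read by thallium flux, with a stated time of 2.5 min (a higher number here means that more compound is needed for the effect, a lower number that less compound is needed), where compound 1 gives 639 nM and compound 3 gives 102 nM. Compound 2 `Cc1c(OCCCCOc2ccc(C(=O)O)cc2)ccc(C(=O)CC2CCCC2)c1C` was also made; for compound 2 in this assay the entry reads "not determined" (no result reported), so no number exists for it. Among the numbers shown, compound 3 stands lowest, with compound 1 its nearest neighbour, and the only measured step, a 6.3-fold lower number from compound 1 to compound 3 (0.80 log units; beyond the scatter), concerns isopropyl in place of cyclopentyl on a saturated chain carbon bound to a carbonyl carbon.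

Compound 4 `Cc1c(OCCCCOc2ccc(F)c(C(=O)O)c2)ccc(C(=O)CC(C)C)c1O` differs from compound 3 at the other end of the molecule: 3-carboxy-4-fluorophenyl in place of 4-carboxy-2-fluorophenyl on an oxygen on a saturated carbon. Both rings carry one carboxylic acid and one fluorine, but compound 4 has them as 3-carboxy-4-fluorophenyl where compound 3 has 4-carboxy-2-fluorophenyl. Going by the values given here, the single measured step concerns the carbonyl side of the core and says nothing about this end, and no measured pair reports a rearrangement of this kind. Such a reshuffling of an acid on the far ring is a real change, so some movement in this assay seems more likely than none, most plausibly upward. Compound 4 is therefore expected to give about 320 nM, within 80 nM to 1600 nM, an estimated step of a 3.1-fold higher number from compound 3 to compound 4 (0.50 log units; beyond the scatter) that reflects uncertainty more than a firm prediction of loss.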

Compound 4, half-maximal effective concentration: 153 nM
For compound 4 the middle estimate is 2.1-fold (0.32 log units) above the measured one; the measured number falls inside the stated range.
By their numbers in this assay, from the lowest: compounds 3 and 4 (each within the scatter of the next); then compound 1.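

In this assay, exchanging 4-carboxy-2-fluorophenyl for 3-carboxy-4-fluorophenyl on the oxygen at the end of the chain gives a 1.5-fold higher number from compound 3 to compound 4 (0.18 log units; within the scatter), so the two values cannot be told apart and these two arrangements of acid and fluorine on the far ring read as equivalent here. Going by these compounds alone, this is the first measured look at that end of the molecule, and it contrasts with the carbonyl side, where the exchange of cyclopentyl for isopropyl gave a 6.3-fold lower number from compound 1 to compound 3 (0.80 log units; beyond the scatter), a step that does stand out from the noise. No measurement of any property of these groups is available to explain the result.

The new ring is shown only with the isopropyl side chain, so it remains open whether the same tolerance would hold with cyclopentyl in its place. Also open, going by these compounds, is what would happen to the number in this assay if a tetrazole or a primary amide replaced the carboxylic acid, or if a chlorine replaced the fluorine on this ring.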